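Swapping the chloropyridinylmethyl arm for a chlorophenylcyclopropyl group

A few compounds are considered here, and "the series" means these few. Any claim that something is new, unique, unknown or untested is made for them only; others in the source may bear on it.

The study concerns inhibition of the thyroid hormone receptor beta, read as an assay on isolated protein for inhibition of thyroid hormone receptor beta (Homo sapiens), read by fluorescence, with a stated time of 30 min; on this read-out higher numbers stand for weaker inhibition and lower numbers for stronger inhibition. Of the compounds shown here, two have been measured. Compound 1 `CCCN(CC1CCOC1)C(=O)c1ccc2oc(NCc3cccc(Cl)c3)nc2c1` gives 214 nM in this assay. Compound 2 `COc1cc(C(=O)N2CCC(O)C(C)C2)cc2nc(NCc3cncc(Cl)c3)oc12` gives 7200 nM in this assay, which is the higher of the two numbers, and the gap to compound 1 lies well beyond the usual scatter of repeated measurements.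

Compound 3 `COc1cc(C(=O)N2CCC(O)C(C)C2)cc2nc(NC3(c4cccc(Cl)c4)CC3)oc12` is not yet measured. It differs from compound 2 in one place only: 1-(3-chlorophenyl)cyclopropyl in place of (5-chloropyridin-3-yl)methyl on a nitrogen on an aromatic ring. The amide portion of compound 2 is retained unchanged.

For the measured compounds named here, no step between two measured compounds is available for this change, so the expectation rests on the two numbers above. Compound 1, which also bears a ring of carbon only with a chlorine on the nitrogen of the shared core, gives 214 nM, and this suggests that compound 3 may move towards a lower number. The step from compound 2 to compound 3 is expected to be a 4.8-fold lower number from compound 2 to compound 3 (0.68 log units; beyond the scatter), a decrease beyond the scatter. Compound 3 is therefore estimated at 1500 nM, with a range from 400 nM to 6000 nM.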

Compound 3, half-maximal inhibitory concentration: 120 nM
Compound 3: middle estimate off by 13-fold (1.10 log units), on the high side, outside the stated range (below it).
By their numbers in this assay, from the lowest: compounds 3 and 1 (each within the scatter of the next); then compound 2.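

In this assay, exchanging the (5-chloropyridin-3-yl)methyl group for the 1-(3-chlorophenyl)cyclopropyl group, with the attachment to a nitrogen on an aromatic ring kept, gives a 60-fold lower number from compound 2 to compound 3 (1.78 log units; beyond the scatter), a large step, while the amide portion stays the same. Until this step, the two measured compounds differed in more than one place, so nothing could be assigned to this position; it now appears that this position alone can shift the number strongly, at least with this amide portion. The change replaces a six-membered aromatic ring with one hetero atom by one of carbon only and also brings in a three-membered ring of carbon only, and no evidence is available on why the number falls.

The compounds shown leave open which part of the change carries the step, and a 3-chlorobenzyl group or a 1-(5-chloropyridin-3-yl)cyclopropyl group on the same nitrogen would separate the two parts. They also leave open whether the 1-(3-chlorophenyl)cyclopropyl group gives a step of similar size with other amide portions, such as a morpholine amide or a piperazine amide.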